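Swapping a fluorinated phenyl ring for an aminopyridine

The compounds below may be only part of what the source reports. "The series", "measured", "known", "first", "only" and "open" are said of these compounds alone.

Compound 1: `Nc1nc(-c2ccc(Cl)cc2)c(CC(=O)O)s1`, > 100000 nM
Compound 2: `O=C(O)Cc1sc(C(Cc2ccccc2)c2ccccc2)nc1-c1ccc(Cl)cc1`, 510 nM
Compound 3: `O=C(O)Cc1sc(C(c2ccc(F)cc2)c2ccc(F)cc2)nc1-c1cc(F)cc(F)c1`, 340 nM

All three were tested in an in vitro functional assay on HEK285-7 cells for antagonist activity at prostaglandin D2 receptor 2 (Homo sapiens), read by BRET and beta-arrestin recruitment; a lower number here means a stronger inhibitor, a higher number a weaker inhibitor. For compound 1 the result is a limit of the assay, not a number: the limit of > 100000 nM in this assay, at which 1 of the 3 values shown sits. Compound 3 has the lower of the two numbers shown, and its nearest neighbour is compound 2, but the gap between them lies within the scatter, so no order between them can be claimed.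

Compound 4, `O=C(O)Cc1sc(C(c2ccc(F)cc2)c2ccc(F)cc2)nc1-c1ccnc(N2CCCC2)c1`, has not been measured yet. It differs from compound 3 in one place:
2-(pyrrolidin-1-yl)pyridin-4-yl in place of 3,5-difluorophenyl on an aromatic carbon

Going by the values given here, no step between two measured compounds matches this change, so its effect can only be guessed. The change is expected to shift the number by a 1.4-fold lower number from compound 3 to compound 4 (0.13 log units; within the scatter), little beyond the scatter. Compound 4 is therefore estimated at 250 nM, within 60 nM to 1500 nM.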

Compound 4, half-maximal inhibitory concentration: > 100000 nM
Compound 4: no number, only a limit (the forecaster's own chance of this, stated with the estimate: 10%); middle value at least 400-fold (2.60 log units) from the limit.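

In this assay, this aromatic carbon of the shared core proves sensitive to what it carries: 2-(pyrrolidin-1-yl)pyridin-4-yl in place of 3,5-difluorophenyl gives an at least 290-fold higher number from compound 3 to compound 4 (2.46 log units; beyond the scatter). Compound 4 gives no number, only a limit of the assay: the limit of > 100000 nM in this assay, at which 2 of the 4 values shown sit.

This change replaces the ring and adds the pyrrolidine at once, so the compounds shown cannot tell which of the two carries the loss. On these data alone, whether a bare pyridin-4-yl ring or a smaller dimethylamino group on the pyridine would give a measurable number stays open.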